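Swapping Nitro for Fluoro on Compound 1

This account rests on a few compounds, and the source may have more. Where it says the series, first, only, none or still open, it means among the compounds named here.

Going by the values given here, in a functional assay on MDA-MB-231 cells (Homo sapiens) for antiproliferative activity, read by MTT assay, with a stated time of 48 h (on this read-out lower numbers stand for stronger inhibition of growth and higher numbers for weaker inhibition of growth), compound 1 `COc1ccc(/C=C2\Cc3c(cc(OC)c(OC)c3OC)C2=O)cc1[N+](=O)[O-]` gives 3490 nM and is the only compound with an actual number so far. Compound 2 `COc1cc2c(c(OC)c1OC)C/C(=C\c1cc(OC)c(OC)c(OC)c1OC)C2=O` gives > 10000 nM in this assay and this is a limit, not a number.

The next compound to be measured is compound 3 `COc1ccc(/C=C2\Cc3c(cc(OC)c(OC)c3OC)C2=O)cc1F` which has not yet been tested. It differs from compound 1 in a single place, with fluoro in place of nitro on an aromatic carbon and the rest of the structure unchanged. That carbon belongs to a six-membered aromatic ring of carbon only and is ortho to a methoxy group.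

Among the compounds with values here, no measured pair of compounds shows what a single change of this kind does, so the direction of any shift remains open. The expectation therefore starts from compound 1 at 3490 nM and assumes no shift beyond the usual scatter. The estimated change is a 1.2-fold lower number from compound 1 to compound 3 (0.07 log units; within the scatter) and it would be too small to read as a real difference. Expected for compound 3 is 3000 nM as the middle value, with 800 nM to 10000 nM as the estimated range.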

Compound 3, concentration for 50% growth inhibition: 521 nM
Compound 3: middle estimate off by 5.8-fold (0.76 log units), on the high side; the measured number lies below the stated range.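

Going by these compounds alone, this is the first measured step at this position: in this assay, the swap gives a 6.7-fold lower number from compound 1 to compound 3 (0.83 log units; beyond the scatter). The rest of the structure is unchanged, so the shift belongs to the group on the aromatic carbon ortho to a methoxy group, and nitro is clearly not needed there for growth inhibition; a much smaller group, with 1 heavy atom instead of 3 and no hydrogen-bond acceptors instead of 2, does better. Compound 2 stays a limit and not a number, and it differs from the others in more than one place, so it adds no step and gives no reason for this shift: the limit of > 10000 nM in this assay, at which 1 of the 3 values shown sits.

A single pair cannot separate what fluoro brings from what the loss of nitro removes, nor say whether size, acceptor count or something else lies behind the step. Plain hydrogen, chloro, a methyl group or an amine on the same carbon would show whether the number follows a trend across groups or whether fluoro is a special case.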